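The source may report more compounds than this note shows. Statements on the series, on what has been measured and on what is new or still open speak of the compounds shown alone.

Compound 1 `O=C1CCC(c2ccc(NC(=O)CCl)cc2)=NN1` gives 0.39 ug/mL in a functional assay for inhibition, with Homo sapiens as the target; a higher number here means that more compound is needed for the effect, a lower number that less compound is needed. Compound 2 `CC(Cl)C(=O)Nc1ccc(C2=NNC(=O)CC2)cc1` carries methyl in place of hydrogen on a saturated chain carbon bound to a carbonyl carbon and a chlorine atom and gives 0.45 ug/mL in this assay, that is a 1.2-fold higher number from compound 1 to compound 2 (0.06 log units; within the scatter). Compound 3 `CC(C)NCC(=O)Nc1ccc(C2=NNC(=O)CC2)cc1` gives about 46.4 ug/mL in this assay; its core differs from the core of compound 1 by isopropylamino in place of chloro on a saturated chain carbon bound to a carbonyl carbon, and that change brought a 120-fold higher number from compound 1 to compound 3 (2.08 log units; beyond the scatter). Compound 4 `CCC(C)NCC(=O)Nc1ccc(C2=NNC(=O)CC2)cc1` is not yet measured. It differs from compound 3 by methyl in place of hydrogen on a saturated chain carbon, two bonds along the chain from an amine nitrogen. Among the measured compounds shown here, this is the same kind of change as the one between compound 1 and compound 2, but the surroundings of the place differ: there the carbon is bound to a carbonyl carbon and a chlorine atom, here it lies two bonds along the chain from an amine nitrogen. Because the earlier step was a 1.2-fold higher number from compound 1 to compound 2 (0.06 log units; within the scatter), a similarly small step is expected here, a 1.1-fold higher number from compound 3 to compound 4 (0.03 log units; within the scatter). Compound 4 is therefore expected to give about 50 ug/mL in this assay, most likely between 20 ug/mL and 125 ug/mL.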

Compound 4, half-maximal effective concentration: about 21.5 ug/mL
Beside the measured number, compound 4's estimate is 2.3-fold (0.37 log units) above it; the measured number falls inside the stated range.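

In this assay, the methyl on a saturated chain carbon, two bonds along the chain from an amine nitrogen, gave a 2.2-fold lower number from compound 3 to compound 4 (0.33 log units; beyond the scatter), while the same kind of change on the chloro compounds gave a 1.2-fold higher number from compound 1 to compound 2 (0.06 log units; within the scatter). Set side by side, these two steps do not clearly differ: the same change on two cores in this assay, a 1.2-fold higher number (0.06 log units; within the scatter) from compound 1 to compound 2 and a 2.2-fold lower number (0.33 log units; beyond the scatter) from compound 3 to compound 4, 2.5-fold (0.40 log units) apart, within the scatter of two such steps. This suggests the change carries across these two cores without a clear difference, but two pairs make no general rule and do not explain the result, and the amine compound still shows a 55-fold higher number from compound 1 to compound 4 (1.74 log units; beyond the scatter) and a 48-fold higher number from compound 2 to compound 4 (1.68 log units; beyond the scatter).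

The compounds shown leave open whether a longer chain, such as (n-pentyl)amino, or a ring, such as cyclopentylamino, in place of (sec-butyl)amino would lower the number further. From the compounds shown here alone, whether bromo in place of chloro would keep the number near that of compound 1 also remains open.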